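Thiazole acids on a shared core: a phenoxyethyl variant

A few compounds are considered here, and "the series" means these few. Any claim that something is new, unique, unknown or untested is made for them only; others in the source may bear on it.

Three compounds of this set carry a value in a functional assay on CHO cells for agonist activity at prostaglandin E2 receptor EP2 subtype (Homo sapiens), read by HTRF and cAMP accumulation, with a stated time of 30 min; on this read-out lower numbers stand for an effect already at smaller amounts and higher numbers for an effect only at larger amounts of compound. Compound 1, `O=C(O)c1csc([C@H]2CC[C@@H]3[C@@H](COc4cccc(F)c4)[C@H](O)C[C@@H]3O2)n1`, gives 5.4 nM in this assay. Compound 2, `O=C(O)c1csc([C@H]2CC[C@@H]3[C@@H](/C=C/CCOc4ccccc4)[C@H](O)C[C@@H]3O2)n1`, gives 3.9 nM; the two values lie within the scatter of each other, so neither can be called the more potent. Compound 3, `O=C(O)CCC[C@H]1CC[C@@H]2[C@@H](/C=C/[C@@H](O)COc3ccccc3)[C@H](O)C[C@@H]2O1`, gives 8900 nM, a number far beyond the scatter from compound 1, and among the three numbers compound 1 stands second highest, nearest to compound 2 and furthest from compound 3.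

Compound 4, `O=C(O)c1csc([C@H]2CC[C@@H]3[C@@H](CCOc4ccccc4)[C@H](O)C[C@@H]3O2)n1`, has not yet been measured. It differs from compound 1 in one place: phenoxymethyl in place of 3-fluorophenoxy on a saturated chain carbon bound to a saturated ring carbon. Going by the values given here, no pair of measured compounds shows this single change, so no measured step guides the estimate. The closest measured neighbour is compound 2, whose phenoxy-bearing side chain also sits on the shared core and whose value of 3.9 nM lies beside that of compound 1. From this, the step from compound 1 to compound 4 is expected to be small, a 1.5-fold higher number from compound 1 to compound 4 (0.17 log units; within the scatter), within or close to the scatter, without a clear direction. Compound 4 is therefore estimated at 8 nM, with a range from 2 nM to 40 nM.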

Compound 4, half-maximal effective concentration: 1.4 nM
Compound 4: the middle estimate sits 5.7-fold (0.76 log units) above what was measured; measured number below the stated range.
By their numbers in this assay, from the lowest: compound 4; then compounds 2 and 1 (each within the scatter of the next); then compound 3.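

Going by these compounds alone, replacing the (3-fluorophenoxy)methyl group with 2-phenoxyethyl on a saturated ring carbon gives a 3.9-fold lower number from compound 1 to compound 4 (0.59 log units; beyond the scatter) in this assay and provides the first measured step at this position. The number at this position therefore responds to the make-up of the side chain, and this change moves it towards an effect at smaller amounts. Nothing measured here explains the step.

The step combines the loss of the fluorine with the change of chain, and these compounds cannot tell the two apart. A 2-(3-fluorophenoxy)ethyl group on the same carbon would separate them, while a 3-phenoxypropyl group would show how the number responds to a longer chain.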